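Inverting one ring stereocentre in a potent receptor inhibitor

The compounds below may be only part of what the source reports. "The series", "measured", "known", "first", "only" and "open" are said of these compounds alone.

The series is built on a shared core, shown in compound 1 `Cc1cc(-c2c(O)nc3cc(Cl)c(C(=O)Nc4ccncn4)cc3c2OCC[C@@H]2CCC[C@H](C)N2)cc(C)c1C` and compound 2 `Cc1cc(C)cc(-c2c(O)nc3cc(Cl)c(C(=O)Nc4ccncn4)cc3c2OCC[C@@H]2CCC[C@H](C)N2)c1`. In an assay on isolated protein for inhibition of Gonadotropin-releasing hormone receptor (Homo sapiens) (on this read-out lower numbers stand for stronger inhibition and higher numbers for weaker inhibition), compound 1 gives 0.6 nM, and in the same this assay compound 2 gives 0.5 nM. Going by the values given here, the one step between them, a 1.2-fold lower number from compound 1 to compound 2 (0.08 log units; within the scatter), replaces a methyl on an aromatic carbon by hydrogen and changes nothing beyond the scatter; compound 2 therefore stands with the lower of the two numbers, but within the scatter of compound 1.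

Compound 3 `Cc1cc(C)cc(-c2c(O)nc3cc(Cl)c(C(=O)Nc4ccncn4)cc3c2OCC[C@@H]2CCC[C@@H](C)N2)c1` keeps every atom and bond of compound 2; the difference is the two compounds have the same atoms and bonds and differ only in configuration as drawn: 1 of 2 stereo elements differ; a stereocentre at a saturated ring carbon is drawn S in compound 2 and R in compound 3. Among the compounds with values here, no measured step touches a change of configuration at this saturated ring carbon, so the only measured step, a 1.2-fold lower number from compound 1 to compound 2 (0.08 log units; within the scatter), does not bear on it. Lacking any such comparison, the expectation for compound 3 rests on compound 2 alone, with a wide margin in either direction. Compound 3 is estimated to give 1.5 nM in this assay, spanning 0.4 nM to 8 nM. The step this estimate implies, a 3.0-fold higher number from compound 2 to compound 3 (0.48 log units; beyond the scatter), is expected rather than known.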

Compound 3, half-maximal inhibitory concentration: 0.5 nM
Estimate against measurement, compound 3: 3.0-fold (0.48 log units) above; the range from low to high includes it.
By their numbers in this assay, from the lowest: compounds 2, 3 and 1 (each within the scatter of the next).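

In this assay, the inversion of this saturated ring carbon from S to R gives no change at the digits printed from compound 2 to compound 3 (within the scatter). Going by these compounds alone, the earlier pair spoke only to a methyl on an aromatic carbon, so this is the first measured comparison of configuration at this position, and it shows that, with the rest of compound 2 kept, the R and S forms cannot be told apart in this read-out. The comparison concerns this single stereocentre and no other part of the structure: the fact that compounds 2 and 3 differ only in the configuration as drawn.

The other stereo element is drawn the same way in all the compounds shown, so the effect of inverting it, alone or together with this ring carbon, remains open, as does whether the R form would read the same with the extra aromatic methyl of compound 1. Also open, from the compounds shown here alone, is whether configuration at this ring carbon would stay equally without consequence if its methyl gave way to an ethyl group, a longer chain or a hydroxymethyl group.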